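Removing One Methoxy Group: Three Limits and an Estimate

This account rests on a few compounds, and the source may have more. Where it says the series, first, only, none or still open, it means among the compounds named here.

Compound 1 `COC(=O)c1c(-c2ccc([N+](=O)[O-])cc2)oc2ccccc2c1=O`: in a functional assay on MCF7 cells (Homo sapiens) for cytotoxicity, read by MTT assay, with a stated time of 6 days (on this read-out lower numbers stand for an effect already at smaller amounts and higher numbers for an effect only at larger amounts of compound), compound 1 gives > 25 ug/mL, which is a limit of the assay and not a number.
Compound 2 `COC(=O)c1c(-c2ccc([N+](=O)[O-])cc2)oc2cc(OC)ccc2c1=O`: in this assay compound 2 gives > 25 ug/mL, again a limit.
Compound 3 `COc1cc(-c2oc3ccccc3c(=O)c2C(=O)O)cc(OC)c1OC`: in this assay compound 3 gives > 25 ug/mL, also a limit.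

Compound 2 and compound 1 differ in one place, (hydrogen in place of methoxy on an aromatic carbon), and the step between them is a step that the two limits leave unreadable from compound 2 to compound 1. The difference between the core of compound 2 and the core of compound 3 is not broken down here.

Compound 4 `COc1cc(OC)cc(-c2oc3ccccc3c(=O)c2C(=O)O)c1` is not yet measured. It differs from compound 3 by hydrogen in place of methoxy on an aromatic carbon. This is the same kind of change as that from compound 2 to compound 1, not the same: in compound 1 the hydrogen enters on a ring that is part of a fused or bridged system of two rings, meta to a fused ring and para to a fused ring, whereas in compound 4 it enters ortho to two methoxy groups and para to a large group.

Among the compounds with values here, the only evidence on the measured steps is the limit of > 25 ug/mL in this assay, at which 3 of the 3 values shown sit. Because a step that the two limits leave unreadable from compound 2 to compound 1 is unreadable, and because of the limit of > 25 ug/mL in this assay, at which 3 of the 3 values shown sit, compound 4 is expected to show a step that the limit leaves unreadable from compound 3 to compound 4. For compound 4 the expected value in this assay is 40 ug/mL, with a range from 12 ug/mL to 150 ug/mL, and a limit rather than a number is the likelier outcome.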

Compound 4, concentration for half-maximal effect: > 25 ug/mL
Compound 4 gave a limit, no number; the forecaster's own chance of this, stated with the estimate: 80%; the middle value lies beyond the limit too.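

In this assay, within the data shown here, compound 3 and compound 4 each give a limit and not a number, so no step between them can be read: the limit of > 25 ug/mL in this assay, at which 4 of the 4 values shown sit.

The compounds shown leave open whether any of the four affects these cells at larger amounts, and whether the methoxy group that differs between compound 3 and compound 4 changes that effect at all.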